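The compounds below may be only part of what the source reports. "The series", "measured", "known", "first", "only" and "open" are said of these compounds alone.

Working notes on the series, toxicity read-out. In a toxicity assay on HepG2 2.2.15 cells (Homo sapiens) for cytotoxicity, read by CellTiter-Glo (a higher number here means that more compound is tolerated, a lower number that less compound is tolerated), compound 1 `O=C1OC(c2ccccc2)CN1c1cnn2c1CN(C(=O)Nc1cc(F)c(F)c(F)c1)C(C1CC1)C2` gives 7410 nM. Compound 2 `O=C(Nc1cc(F)c(F)c(F)c1)N1CCCn2ncc(N3CC(c4ccccc4)CC3=O)c2C1` gives > 2000 nM, which is a limit and not a number. Compound 3 `Cc1cnc(C2CC(=O)N(c3cnn4c3CN(C(=O)Nc3cc(F)c(F)c(F)c3)C(C3CC3)C4)C2)s1` gives 96200 nM, the higher of the two actual numbers in the series. The gap between them is a 13-fold higher number from compound 1 to compound 3 (1.11 log units; beyond the scatter), which lies beyond the scatter.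

The next compound is compound 4 `O=C1CC(c2nccs2)CN1c1cnn2c1CN(C(=O)Nc1cc(F)c(F)c(F)c1)C(C1CC1)C2`. Its change from compound 3 is hydrogen in place of methyl on an aromatic carbon. In words, hydrogen replaces methyl on an aromatic carbon next to the ring sulfur, so 5-methyl-1,3-thiazol-2-yl becomes 1,3-thiazol-2-yl.

Within the data shown here, only one measured step bears on this, and only loosely. The reading of a 13-fold higher number from compound 1 to compound 3 (1.11 log units; beyond the scatter) belongs to the exchange of an entire group, so it does not give the size of a methyl change on its own. Among the measured compounds shown here, no measured pair isolates that methyl. A large step in this assay is therefore not expected, and the working expectation is a small move to a lower number, within the scatter.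

The estimated step is a 1.4-fold lower number from compound 3 to compound 4 (0.14 log units; within the scatter). For compound 4 the expected value is 70000 nM, with an estimated range from 25000 nM to 170000 nM.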

Compound 4, half-maximal cytotoxic concentration: 115000 nM
Beside the measured number, compound 4's estimate is 1.6-fold (0.22 log units) below it; low and high end bracket the measured number.
By their numbers in this assay, from the lowest: compound 1; then compounds 3 and 4 (each within the scatter of the next).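

In this assay, among these compounds, this is the first change confined to the aromatic carbon next to the ring sulfur, and the exchange of methyl for hydrogen gives a 1.2-fold higher number from compound 3 to compound 4 (0.08 log units; within the scatter), so the methyl does not separate the two compounds. The large gap to the 2-oxo-5-phenyl-1,3-oxazolidin-3-yl group also stands without the methyl, at a 16-fold higher number from compound 1 to compound 4 (1.19 log units; beyond the scatter), so the gap seen earlier does not depend on that methyl. Nothing given here accounts for why either the methyl exchange or the larger group exchange reads as it does.

The step from compound 1 exchanges the whole group on the aromatic carbon, which leaves open whether the 1,3-thiazol-2-yl ring, the 2-oxopyrrolidin-1-yl ring or the two together carry the higher number. Also open is how a chlorine, an amine, a carboxylic acid or a longer chain on the carbon next to the ring sulfur would read in this assay, since methyl and hydrogen are the only two substituents shown there.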